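A few compounds are considered here, and "the series" means these few. Any claim that something is new, unique, unknown or untested is made for them only; others in the source may bear on it.

Compound 3 `CSc1ccc(C2=NN(C(=S)Nc3ccccc3)C(c3ccc4c(c3)OCCO4)C2)cc1` gives 159000 nM in a functional assay on A-375 cells (Homo sapiens) for antiproliferative activity, read by MTT assay, with a stated time of 48 h (a lower number here means a stronger inhibitor of growth, a higher number a weaker inhibitor of growth), the highest of the three numbers measured; compound 1 `S=C(Nc1ccccc1)N1N=C(c2ccc(Br)cc2)CC1c1ccc2c(c1)OCCO2` gives 470 nM and compound 2 `FC(F)(F)c1ccc(C2=NN(C(=S)Nc3ccccc3)C(c3ccc4c(c3)OCCO4)C2)cc1` gives 43500 nM. Compound 4 `O=[N+]([O-])c1ccc(C2=NN(C(=S)Nc3ccccc3)C(c3ccc4c(c3)OCCO4)C2)cc1` differs from compound 3 by nitro in place of methylsulfanyl on an aromatic carbon. Within the data shown here, no measured step exchanges methylsulfanyl for nitro. The steps at this position were a 340-fold higher number from compound 1 to compound 3 (2.53 log units; beyond the scatter) and a 3.7-fold higher number from compound 2 to compound 3 (0.56 log units; beyond the scatter), so both other groups seen there gave lower numbers than methylsulfanyl. A decrease in this assay is therefore expected for compound 4, probably of modest size because the step of a 3.7-fold higher number from compound 2 to compound 3 (0.56 log units; beyond the scatter) was modest, with a wide margin. Compound 4 is thus expected at 30000 nM, between 5000 nM and 150000 nM, an expected step of a 5.3-fold lower number from compound 3 to compound 4 (0.72 log units; beyond the scatter).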

Compound 4, concentration for 50% growth inhibition: 78100 nM
Compound 4: the middle estimate sits 2.6-fold (0.42 log units) below what was measured; measured number inside the range.
By their numbers in this assay, from the lowest: compound 1; then compounds 2 and 4 (each within the scatter of the next); then compound 3.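

In this assay, nitro is a further group at this position that stands far from bromo, with a 170-fold higher number from compound 1 to compound 4 (2.22 log units; beyond the scatter), so the low number of compound 1 now stands apart from three analogues rather than two. Nitro and trifluoromethyl cannot be told apart, with a 1.8-fold higher number from compound 2 to compound 4 (0.25 log units; within the scatter), while a 2.0-fold lower number from compound 3 to compound 4 (0.31 log units; beyond the scatter) is only a modest step. Nothing available here explains these differences. On these data alone, whether chloro or iodo at this position would give a number close to that of compound 1 stays open, and so does the place of an amine or methoxy.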